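This account rests on a few compounds, and the source may have more. Where it says the series, first, only, none or still open, it means among the compounds named here.

Measured compounds:
- compound 1 `CC(C)=CC[C@@H](OC[C@@H](C)O)C1=CC(=O)c2c(O)ccc(O)c2C1=O`: 14300 nM
- compound 2 `CCCCC(O)CC(=O)O[C@H](CC=C(C)C)C1=CC(=O)c2c(O)ccc(O)c2C1=O`: 45300 nM
- compound 3 `CC(C)=CC[C@@H](OCCO)C1=CC(=O)c2c(O)ccc(O)c2C1=O`: 9900 nM

All three were tested in a functional assay on DU-145 cells (Homo sapiens) for cytotoxicity, read by MTT assay; a lower number here means a stronger inhibitor, a higher number a weaker inhibitor. Compound 1 sits second highest of the three numbers; compound 3 lies close to it, within the scatter, as a 1.4-fold lower number from compound 1 to compound 3 (0.16 log units; within the scatter) shows, while compound 2 stands clearly apart, as a 3.2-fold higher number from compound 1 to compound 2 (0.50 log units; beyond the scatter) shows.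

Compound 4 `CCC(C)(O)CC(=O)O[C@H](CC=C(C)C)C1=CC(=O)c2c(O)ccc(O)c2C1=O` has not yet been measured. It differs from compound 1 in one place: (2-hydroxy-2-methylbutyl)carbonyl in place of 2-hydroxypropyl on an oxygen on a saturated carbon. The ether oxygen of compound 1 thus becomes part of an ester, as already happened on the way from compound 1 to compound 2.

That earlier step is the one that bears on this change: a 3.2-fold higher number from compound 1 to compound 2 (0.50 log units; beyond the scatter), a modest rise, and the related move a 4.6-fold lower number from compound 2 to compound 3 (0.66 log units; beyond the scatter) points the same way from the other side. For the measured compounds named here, the chain entering compound 4 is shorter and branched compared with that of compound 2, but the only evidence on hand is this one ester step. A modest rise in this assay is therefore expected for compound 4, about a 2.4-fold higher number from compound 1 to compound 4 (0.39 log units; beyond the scatter). The value for compound 4 is estimated at 35000 nM, with a likely range from 14000 nM to 90000 nM.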

Compound 4, half-maximal inhibitory concentration: 16000 nM
For compound 4 the middle estimate is 2.2-fold (0.34 log units) above the measured one; low and high end bracket the measured number.
By their numbers in this assay, from the lowest: compounds 3, 1 and 4 (each within the scatter of the next); then compound 2.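

An ester on this oxygen does not by itself move the number in this assay beyond the scatter, as a 1.1-fold higher number from compound 1 to compound 4 (0.05 log units; within the scatter) and a 1.6-fold higher number from compound 3 to compound 4 (0.21 log units; within the scatter) both show. The ester chain does count, however: a 2.8-fold lower number from compound 2 to compound 4 (0.45 log units; beyond the scatter) comes with 1-hydroxy-1-methylpropyl in place of 1-hydroxypentyl on a saturated chain carbon bound to a carbonyl carbon. The rise seen earlier therefore goes with one particular ester and not with both esters shown here, although two esters are a small sample.

From the compounds shown here alone, it remains open whether a chain carrying an amine or a carboxylic acid on this oxygen, or a chain longer than 1-hydroxypentyl, would shift the number. Nothing measured here accounts for the gap between the two esters.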